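Pyridine sulfonylamides: methyl for bromo on a second core

A few compounds are considered here, and "the series" means these few. Any claim that something is new, unique, unknown or untested is made for them only; others in the source may bear on it.

Compound 1 `O=C(NS(=O)(=O)c1ccc(Br)cc1)c1ccncc1` gives 8700 nM in a functional assay on MCF7 cells (Homo sapiens) for antiproliferative activity, read by colorimetric assay and MTT assay, with a stated time of 48 h; a higher number here means a weaker inhibitor, a lower number a stronger inhibitor. Compound 2 `Cc1ccc(S(=O)(=O)NC(=O)c2ccncc2)cc1` gives 14100 nM in this assay; the step of a 1.6-fold higher number from compound 1 to compound 2 (0.21 log units; within the scatter) follows from methyl in place of bromo on an aromatic carbon. Compound 3 `O=C(NS(=O)(=O)c1ccc(Br)cc1)c1ccccn1` gives 6800 nM in this assay; its core differs from the core of compound 1 by pyridin-2-yl in place of pyridin-4-yl on a carbonyl carbon, a step of a 1.3-fold lower number from compound 1 to compound 3 (0.11 log units; within the scatter). Compound 4 `Cc1ccc(S(=O)(=O)NC(=O)c2ccccn2)cc1` has not yet been measured. It differs from compound 3 by methyl in place of bromo on an aromatic carbon, the same change as that from compound 1 to compound 2, at a place described in the same words. The step is expected to match the earlier one and is estimated as a 1.5-fold higher number from compound 3 to compound 4 (0.19 log units; within the scatter) in this assay, resting on a 1.6-fold higher number from compound 1 to compound 2 (0.21 log units; within the scatter). Compound 4 is accordingly estimated at 10500 nM, with a range from 5500 nM to 20000 nM.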

Compound 4, half-maximal inhibitory concentration: 11800 nM
Estimate against measurement, compound 4: 1.1-fold (0.05 log units) below; measured number inside the range.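

Methyl in place of bromo on an aromatic carbon gives a 1.7-fold higher number from compound 3 to compound 4 (0.24 log units; within the scatter) in this assay, and the step shows no difference between the two cores: the same change on two cores in this assay, a 1.6-fold higher number (0.21 log units; within the scatter) from compound 1 to compound 2 and a 1.7-fold higher number (0.24 log units; within the scatter) from compound 3 to compound 4, 1.1-fold (0.03 log units) apart, within the scatter of two such steps. Pyridin-2-yl in place of pyridin-4-yl on a carbonyl carbon gives a 1.2-fold lower number from compound 2 to compound 4 (0.08 log units; within the scatter), and this step also agrees between the two cores: the same change on two cores in this assay, a 1.3-fold lower number (0.11 log units; within the scatter) from compound 1 to compound 3 and a 1.2-fold lower number (0.08 log units; within the scatter) from compound 2 to compound 4, 1.1-fold (0.03 log units) apart, within the scatter of two such steps. Going by these compounds alone, with every one of these steps within the scatter, the agreement shows only that neither change departs measurably from one core to the other in these compounds; it does not show that either change has a real effect, or that it would carry to any further core.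

The compounds shown leave open how an amine, a carboxylic acid or a longer chain at the same aromatic carbon would read, and whether any such group would give a step beyond the scatter.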